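The source may hold more compounds than are shown below. What is called first, only, known or untested is meant among the compounds shown, and "the series" means these compounds.

Working notes on the series. Compound 1 `N#C[C@@H]1CCCN1C(=O)[C@@H]1C[C@H](CO)CN1` is the reference for the step considered here. In an assay on the whole organism (plasma, strain Sprague-Dawley) for inhibition of Dipeptidyl peptidase 4 (Rattus norvegicus), with a stated time of 6 h, at a dose of 1 mg/kg by the oral route (a lower number here means less inhibition, a higher number more inhibition at the dose given (going by the name of the read-out)), compound 1 gives 64%, the lowest of the three numbers in hand, and its gap to each of the other two lies beyond the scatter. Compound 2 `C[C@@H]1N[C@H](C(=O)N2CCC[C@H]2C#N)C[C@@H]1C(=O)N1CCC1` gives 94% in this assay, and compound 3 `C[C@@H]1N[C@H](C(=O)N2CCC[C@H]2C#N)C[C@@H]1C(=O)N1CCCC1` gives 94%; the single-point step between them, no change at the digits printed from compound 2 to compound 3 (within the scatter), shows that exchanging the ring on the carbonyl carbon leaves the read-out where it was.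

Compound 4 `CCNC(=O)[C@@H]1CN[C@H](C(=O)N2CCC[C@H]2C#N)C1` has not been measured in this assay. It differs from compound 1 as follows: ethylcarbamoyl in place of hydroxymethyl on a saturated ring carbon. Going by the values given here, no measured step covers this exchange directly; compounds 2 and 3 are not single-point neighbours of compound 1, so of them only the values themselves can be read, and both stand beyond the scatter above compound 1. The step from compound 2 to compound 3 speaks only to the amide ring size and bears little on this change. The expectation for compound 4 is therefore an upward step, a number 20 percentage points higher from compound 1 to compound 4 (beyond the scatter), though with wide uncertainty. Compound 4 is estimated at 84% in this assay, with a range from 64% to 97%.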

Compound 4, a percentage reported as inhibition, in the whole organism at one dose (the size of the read-out at that dose, not a potency): 60%
Beside the measured number, compound 4's estimate is 24 percentage points above it; measured number outside the range, below it.
By their numbers in this assay, from the lowest: compounds 4 and 1 (each within the scatter of the next); then compounds 2 and 3 (each within the scatter of the next).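

In this assay, ethylcarbamoyl with its 5 heavy atoms in place of hydroxymethyl with its 2, on a saturated ring carbon two ring bonds from the ring nitrogen, gives a number 4 percentage points lower from compound 1 to compound 4 (within the scatter). This position of the core of compound 1 therefore accepts the longer group carrying a carbonyl, and at this single dose and time the read-out does not separate the two groups; as the read-out is the size of the effect at one dose, this says nothing about potency. No supporting measurement bears on this result, so the data give no account of it.

Open is whether the same holds for an aminomethyl group, a carboxylic acid or a longer chain such as butylcarbamoyl on this ring carbon, since the compounds shown carry only two groups here. Going by these compounds, one exchange also sets no trend with chain length, and whether the two groups would stay level at a lower dose or a later time remains open.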